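Replacing the aniline arm: expectations for compound 4

The source may hold more compounds than are shown below. What is called first, only, known or untested is meant among the compounds shown, and "the series" means these compounds.

The series is built on the core shown in compound 1, `COc1cc(-n2cnc3ccc(-c4cccc(N)c4)cc32)cc(OC)c1OC`, which in a functional assay on MCF7 cells (Homo sapiens) for antiproliferative activity, read by MTT assay, with a stated time of 72 h (a lower number here means a stronger inhibitor, a higher number a weaker inhibitor), gives 180 nM. That is the lowest of the two numbers recorded. Compound 3, `COc1cc(-n2cnc3ccc(-c4cccc([N+](=O)[O-])c4)cc32)cc(OC)c1OC`, gives 4560 nM in this assay; the gap is a 25-fold higher number from compound 1 to compound 3 (1.40 log units; beyond the scatter). Compound 2, `COc1cc(-n2cnc3ccc(-c4ccccc4Cl)cc32)cc(OC)c1OC`, reaches only the limit of this assay, > 10000 nM. A further step is an at least 2.1-fold lower number from compound 2 to compound 3 (0.34 log units; beyond the scatter).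

The unmeasured compound 4, `COc1ccc(-c2ccc3ncn(-c4cc(OC)c(OC)c(OC)c4)c3c2)cc1F`, differs from compound 1 in one place: 3-fluoro-4-methoxyphenyl in place of 3-aminophenyl on an aromatic carbon. Both measured steps that start from compound 1 bear on this change, as each also takes away the amino group: a 25-fold higher number from compound 1 to compound 3 (1.40 log units; beyond the scatter) and an at least 55-fold higher number from compound 1 to compound 2 (1.74 log units; beyond the scatter). Neither step shows the fluoro-methoxy pattern itself, so the direct precedent is missing; what the two steps share is that every replacement of the amino group so far has moved the number upward by a large amount. On that basis a higher number is expected for compound 4 as well, probably a large step, though whether it will reach the limit of the assay cannot be told from the two steps alone.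

Compound 4 is therefore estimated at 1800 nM, with a range from 350 nM to 9000 nM. This estimate corresponds to an expected step of a 10-fold higher number from compound 1 to compound 4 (1.00 log units; beyond the scatter).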

Compound 4, half-maximal inhibitory concentration: 520 nM
Compound 4: the middle estimate sits 3.5-fold (0.54 log units) above what was measured; the range from low to high includes it.
By their numbers in this assay, from the lowest: compound 1; then compound 4; then compound 3. At a limit, above all of these: compound 2.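

In this assay, 3-fluoro-4-methoxyphenyl takes the place of 3-aminophenyl at a modest cost, a 2.9-fold higher number from compound 1 to compound 4 (0.46 log units; beyond the scatter), so a large loss does not follow from removing the amino group alone, although compound 1 keeps the lowest number of the values shown. The groups without the amino group also differ widely among themselves, so what enters at this position counts as well as what leaves: an 8.8-fold lower number from compound 3 to compound 4 (0.94 log units; beyond the scatter), and an at least 19-fold lower number from compound 2 to compound 4 (1.28 log units; beyond the scatter). Compound 2 stands at a limit and not at a number, so the last of these steps is only a bound: the limit of > 10000 nM in this assay, at which 1 of the 4 values shown sits.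

The compounds shown leave open whether the fluoro or the methoxy substituent accounts for the standing of compound 4, since both enter together in a single change. They also leave open how a hydroxyl, a dimethylamino group or a carboxylic acid at the place of the amino group, on an otherwise unchanged phenyl ring, would compare with compound 1 at 180 nM.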